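A few compounds are considered here, and "the series" means these few. Any claim that something is new, unique, unknown or untested is made for them only; others in the source may bear on it.

For the measured compounds named here, in a functional assay on K562 cells (Homo sapiens) for antiproliferative activity, read by MTT assay, with a stated time of 48 h (a higher number here means a weaker inhibitor, a lower number a stronger inhibitor), compound 2 `Cn1cc(C2=C(c3nn(CCCN4CCCCC4)c4ncccc34)C(=O)N(c3ccccc3)C2=O)c2ccccc21` gives 3790 nM, the only actual number so far. Compound 1 `Cn1cc(C2=C(c3nn(CCCn4cncn4)c4ncccc34)C(=O)N(c3ccccc3)C2=O)c2ccccc21` reports only a limit, > 100000 nM. Compound 3 `Cn1cc(C2=C(c3nn(CCn4ccnc4)c4ncccc34)C(=O)N(c3ccccc3)C2=O)c2ccccc21` is next: 1H-imidazol-1-yl in place of (piperidin-1-yl)methyl on a saturated chain carbon, two bonds along the chain from an aromatic nitrogen. Read one bond further out, 2-(1H-imidazol-1-yl)ethyl replaces 3-(piperidin-1-yl)propyl. Going by the values given here, one measured step bears on this, an at least 26-fold lower number from compound 1 to compound 2 (1.42 log units; beyond the scatter), where piperidin-1-yl replaced 1H-1,2,4-triazol-1-yl. Among the compounds with values here, compound 3 again carries a five-membered aromatic ring at the chain end, so much of that step is expected to reverse in this assay, although no measured step covers the change in chain. The expected step is a 7.9-fold higher number from compound 2 to compound 3 (0.90 log units; beyond the scatter), a large rise in the number. The estimate for compound 3 is 30000 nM, with an expected range of 8000 nM to 100000 nM.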

Compound 3, half-maximal inhibitory concentration: 26400 nM
Beside the measured number, compound 3's estimate is 1.1-fold (0.06 log units) above it, within the range that was stated.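

In this assay, moving from 3-(piperidin-1-yl)propyl to 2-(1H-imidazol-1-yl)ethyl gives a 7.0-fold higher number from compound 2 to compound 3 (0.84 log units; beyond the scatter), leaving compound 2 the most potent of the three shown. The two compounds with a five-membered aromatic ring at the chain end are also separated, with an at least 3.7-fold lower number from compound 1 to compound 3 (0.57 log units; beyond the scatter), so such a ring does not by itself place a compound at the level of compound 1. That step is only a bound, since the reading for compound 1 is a limit and not a number: the limit of > 100000 nM in this assay, at which 1 of the 3 values shown sits.

On these data alone, in compound 3, the chain and the end group change together, so the share of each in these steps stays open. A 2-(piperidin-1-yl)ethyl or 3-(1H-imidazol-1-yl)propyl chain would separate the two, and a morpholin-4-yl end group would test whether the piperidine ring can be replaced.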